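Swapping Fluorine for Bromine on the Aniline Ring

The source may report more compounds than this note shows. Statements on the series, on what has been measured and on what is new or still open speak of the compounds shown alone.

Two compounds share one core and differ only in the ring attached to a nitrogen on an aromatic ring. Compound 1 `C=CC(=O)Nc1cccc(NC(=O)CSc2nc(Nc3ccccc3Br)c3ccccc3n2)c1` carries a 2-bromophenyl there; in a functional assay on NCI-H1975 cells (Homo sapiens) for inhibition, read by MTT assay, with a stated time of 72 h (a higher number here means a weaker inhibitor, a lower number a stronger inhibitor), compound 1 gives 19300 nM. Compound 2 `C=CC(=O)Nc1cccc(NC(=O)CSc2nc(Nc3cccc(F)c3)c3ccccc3n2)c1` carries a 3-fluorophenyl instead, and in this assay compound 2 gives 2030 nM. Going by the values given here, that change is the only measured step: a 9.5-fold lower number from compound 1 to compound 2 (0.98 log units; beyond the scatter). Among the compounds with values here, compound 2 thus holds the lowest of the two numbers, with compound 1 as its only neighbour, a higher number by a step beyond the scatter.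

Compound 3 `C=CC(=O)Nc1cccc(NC(=O)CSc2nc(Nc3cccc(Br)c3)c3ccccc3n2)c1` keeps the same attachment as compound 2 and changes only the halogen: bromo in place of fluoro on an aromatic carbon. Within the data shown here, no measured step isolates this swap; the one step from compound 1 to compound 2 moves both the halogen and where it sits at once, so it offers only weak guidance. The expectation is therefore a step no larger than the scatter, a 1.4-fold lower number from compound 2 to compound 3 (0.13 log units; within the scatter), in this assay. Compound 3 is expected to give about 1500 nM, with a range from 400 nM to 6000 nM.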

Compound 3, half-maximal inhibitory concentration: 12100 nM
Compound 3: middle estimate off by 8.1-fold (0.91 log units), on the low side; the whole stated range lies below it.
By their numbers in this assay, from the lowest: compound 2; then compounds 3 and 1 (each within the scatter of the next).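

In this assay, the halogen itself turns out to count on this aniline ring: with its place unchanged, bromo in place of fluoro gives a 6.0-fold higher number from compound 2 to compound 3 (0.78 log units; beyond the scatter). Moving the bromine, by contrast, shows no change that can be told from noise, since 3-bromophenyl in place of 2-bromophenyl gives a 1.6-fold lower number from compound 1 to compound 3 (0.20 log units; within the scatter). The single earlier step had changed the halogen and its place together, and these two new steps suggest that, among these three compounds, the gain seen with compound 2 goes with fluoro rather than with the shift to the 3-position, though no available evidence accounts for the difference between the two halogens.

Going by these compounds, what remains open is whether compound 2 stands out for fluoro specifically or whether other small groups in that place, such as chloro, methyl or methoxy, or plain phenyl with no group at all, would give similar numbers. On these data alone, it is also open whether the place of the halogen counts for fluoro as little as it does for bromo, which a 2-fluorophenyl or 4-fluorophenyl compound would show.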